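The source may report more compounds than this note shows. Statements on the series, on what has been measured and on what is new or still open speak of the compounds shown alone.

Working notes on the series. In a functional assay on SK-MEL-2 cells (Homo sapiens) for inhibition, read by sulforhodamine B assay, with a stated time of 48 h (a higher number here means a weaker inhibitor of growth, a lower number a stronger inhibitor of growth), compound 1 `Cc1ccc(C2=NN(c3ccc(S(C)(=O)=O)cc3)C(=O)CC2)cc1` gives 430 nM and compound 2 `Cc1cc(O)ccc1C1=NN(c2ccc(S(C)(=O)=O)cc2)C(=O)CC1` gives 3480 nM. Compound 2 therefore holds the higher of the two numbers, making it the weaker inhibitor of growth of this pair.

The next compound is compound 3 `CCc1ccc(C2=NN(c3ccc(S(C)(=O)=O)cc3)C(=O)CC2)cc1`, with 4-ethylphenyl in place of 4-hydroxy-2-methylphenyl on a carbon with a double bond to nitrogen. Going by the values given here, only one measured step bears on this change: an 8.1-fold higher number from compound 1 to compound 2 (0.91 log units; beyond the scatter), which came with 4-hydroxy-2-methylphenyl replacing 4-methylphenyl. Compound 3 loses that same 4-hydroxy-2-methylphenyl group, so a step of similar size in the opposite direction is expected in this assay, towards a lower number. Among the compounds with values here, no measured compound carries 4-ethylphenyl, so the effect of that group is untested and the return may be incomplete.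

The expected change is a 5.8-fold lower number from compound 2 to compound 3 (0.76 log units; beyond the scatter), which lies a little short of the full reversal. Compound 3 is estimated at 600 nM, with an expected range of 200 nM to 1800 nM.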

Compound 3, concentration for 50% growth inhibition: 900 nM
Compound 3: the middle estimate sits 1.5-fold (0.18 log units) below what was measured; the range from low to high includes it.
By their numbers in this assay, from the lowest: compound 1; then compound 3; then compound 2.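

In this assay, the two alkyl-substituted aryl groups now stand together on the low side of the series: a 3.9-fold lower number from compound 2 to compound 3 (0.59 log units; beyond the scatter), so a group without the hydroxyl and without the 2-methyl recovers much of the ground lost with 4-hydroxy-2-methylphenyl. Extending the 4-methylphenyl group to 4-ethylphenyl is not neutral, however, as methyl in place of hydrogen on the saturated chain carbon bound to an aromatic carbon gives a 2.1-fold higher number from compound 1 to compound 3 (0.32 log units; beyond the scatter), a modest step that leaves compound 1 with the lowest number of the three and thus the strongest inhibitor of growth so far. No supporting measurement accounts for either step.

Compound 2 and compound 3 differ in both the hydroxyl and the methyl pattern, so these compounds cannot separate the contribution of the hydroxyl from that of the 2-methyl group, and a 4-hydroxyphenyl or a 2-methylphenyl group would be needed to pull the two apart. Also open, going by these compounds, is whether the upward trend continues with a longer chain such as propyl, and how an amine or a carboxylic acid at the same carbon-bound aryl group would read.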